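A few compounds are considered here, and "the series" means these few. Any claim that something is new, unique, unknown or untested is made for them only; others in the source may bear on it.

Compound 1 `O=C(/C=C/c1ccc(Cl)c([N+](=O)[O-])c1)/C=C/c1ccccc1Oc1ncnc2ccc(Cl)cc12` and compound 3 `O=C(/C=C/c1ccc(Cl)c(Cl)c1)/C=C/c1ccccc1Oc1ncnc2ccc(Cl)cc12` share one core and differ only by chloro in place of nitro on an aromatic carbon. In a functional assay on MGC-803 cells (Homo sapiens) for inhibition, read by MTT assay, with a stated time of 72 h (on this read-out lower numbers stand for stronger inhibition and higher numbers for weaker inhibition), compound 1 gives 5320 nM, while compound 3 gives 16200 nM, so the exchange shows as a 3.0-fold higher number from compound 1 to compound 3 (0.48 log units; beyond the scatter). Compound 2 `O=C(/C=C/c1ccc(Oc2ncnc3ccc(Cl)cc23)cc1)/C=C/c1ccc(Cl)c([N+](=O)[O-])c1` has the same atoms as compound 1 joined differently; how the two cores differ is not broken down here. In this assay compound 2 gives 7190 nM. Compound 4 `O=C(/C=C/c1ccc(Oc2ncnc3ccc(Cl)cc23)cc1)/C=C/c1ccc(Cl)c(Cl)c1` has not yet been measured in this assay. It differs from compound 2 by chloro in place of nitro on an aromatic carbon, the same change made between compound 1 and compound 3, at a place described in identical words. Among the compounds with values here, a step of a 2.9-fold higher number from compound 2 to compound 4 (0.47 log units; beyond the scatter) is expected, resting on the one earlier step of a 3.0-fold higher number from compound 1 to compound 3 (0.48 log units; beyond the scatter). Compound 4 is therefore estimated at 21000 nM, between 9000 nM and 48000 nM.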

Compound 4, half-maximal inhibitory concentration: 16900 nM
The estimate for compound 4 lay 1.2-fold (0.09 log units) above the measured number; the range from low to high includes it.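

In this assay the exchange of nitro for chloro gives a 2.4-fold higher number from compound 2 to compound 4 (0.37 log units; beyond the scatter) and so points the same way as it does on the core of compound 1. The two steps also agree in size: the same change on two cores in this assay, a 3.0-fold higher number (0.48 log units; beyond the scatter) from compound 1 to compound 3 and a 2.4-fold higher number (0.37 log units; beyond the scatter) from compound 2 to compound 4, 1.3-fold (0.11 log units) apart, within the scatter of two such steps. Within the data shown here, this shows that the change carried over between these two cores in this one assay, but with only two pairs it does not show that it would hold on any other core, and it gives no reason for the step.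

The compounds shown leave open whether other groups at this place, such as an amine, a methoxy group or a carboxylic acid, would give a lower or a higher number than nitro or chloro. They also leave open whether the change from 4-chloro-3-nitrophenyl to 3,4-dichlorophenyl behaves alike on other cell lines.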